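Alkyne to alkene on the sulfonyl aryl group

The source may report more compounds than this note shows. Statements on the series, on what has been measured and on what is new or still open speak of the compounds shown alone.

Measured compounds in a functional assay on A-375 cells (Homo sapiens) for antiproliferative activity, read by trypan blue exclusion, with a stated time of 48 h, tested at 5 uM; on this read-out higher numbers stand for a weaker effect at the one concentration tested and lower numbers for a stronger effect:
compound 1 `CCCCC#Cc1ccc(S(=O)(=O)Nc2cccc(-c3csc(NC(C)=O)n3)c2)cc1` gives 9.3%;
compound 2 `CC(=O)Nc1nc(-c2cccc(NS(=O)(=O)c3ccc(C#CC4CCCCC4)cc3)c2)cs1` gives 1.2%;
compound 3 `CCCCCCC#Cc1cccc(S(=O)(=O)Nc2cccc(-c3csc(NC(C)=O)n3)c2)c1` gives 1.2%.

Among these three numbers, compound 1 carries the largest figure, yet all three lie within the scatter of one another, so none can be set apart as weaker or stronger. Going by the values given here, the one step that is computed, a number 8.1 percentage points lower from compound 1 to compound 2 (within the scatter), is within the scatter.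

Compound 4 `CCCCCC/C=C\c1ccc(S(=O)(=O)Nc2cccc(-c3csc(NC(C)=O)n3)c2)cc1` differs from compound 1 in one place: a group of 8 heavy atoms (8 carbon; no ring) in place of a group of 6 heavy atoms (6 carbon; no ring), on an aromatic carbon. Among the compounds with values here, no measured pair shows a double bond replacing a triple bond on this aromatic carbon, so the only guidance is indirect. The step from compound 1 to compound 2 changed the group on the triple-bonded carbon without moving the number beyond the scatter, and compound 3, with a longer chain, gives a similar figure. On that basis no step beyond the scatter is expected; compound 4 is estimated to give 9% (range 1% to 25%), an expected step of a number 0.3 percentage points lower from compound 1 to compound 4 (within the scatter).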

Compound 4, a percentage reported as activity, at one concentration (the size of the read-out at that concentration, not a potency): 2.3%
Estimate against measurement, compound 4: 6.7 percentage points above, and the stated range covers the measured number.
By their numbers in this assay, from the lowest: compounds 2, 3, 4 and 1 (each within the scatter of the next).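

Going by these compounds alone, on the aromatic carbon para to a large group, a chain with a double bond outside the aromatic rings takes the place of the triple bond held by the earlier compounds, and in this assay this step lies within the scatter (a number 7 percentage points lower from compound 1 to compound 4 (within the scatter)). The step from a group with a six-membered non-aromatic ring to one with no ring, both of 8 heavy atoms, also lies within the scatter (a number 1.1 percentage points higher from compound 2 to compound 4 (within the scatter)), so no effect of either change can be read at this position. No measurement is at hand that bears on the reason for this result.

The double bond and the longer chain enter together, so the two changes cannot be told apart here. Going by these compounds, whether an amine or a carboxylic acid on this aromatic carbon would give a number beyond the scatter remains open.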